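From trifluoromethyl to nitro on the phenoxy group

The source may hold more compounds than are shown below. What is called first, only, known or untested is meant among the compounds shown, and "the series" means these compounds.

In a functional assay with Homo sapiens as the target (a lower number here means a stronger inhibitor, a higher number a weaker inhibitor), compound 1 `CC(C)[C@H](NC(=O)COc1cccc2ccccc12)C(=O)N[C@@H](CC(=O)O)C(=O)COc1ccc(-c2ccccc2)cc1` gives 38700 nM, compound 2 `CC(C)[C@H](NC(=O)COc1cccc2ccccc12)C(=O)N[C@@H](CC(=O)O)C(=O)COc1cc(F)ccc1F` gives 19700 nM and compound 3 `CC(C)[C@H](NC(=O)COc1cccc2ccccc12)C(=O)N[C@@H](CC(=O)O)C(=O)COc1cccc(C(F)(F)F)c1F` gives 18200 nM. The measured steps are small: a 2.0-fold lower number from compound 1 to compound 2 (0.29 log units; within the scatter), a 2.1-fold lower number from compound 1 to compound 3 (0.33 log units; beyond the scatter) and a 1.1-fold lower number from compound 2 to compound 3 (0.03 log units; within the scatter). Compound 3 therefore stands level with compound 2 and modestly apart from compound 1. Compound 4 `CC(C)[C@H](NC(=O)COc1cccc2ccccc12)C(=O)N[C@@H](CC(=O)O)C(=O)COc1ccc([N+](=O)[O-])cc1F` keeps the shared core but carries 2-fluoro-4-nitrophenyl in place of 2-fluoro-3-(trifluoromethyl)phenyl on an oxygen on a saturated carbon. Within the data shown here, no measured compound carries a nitro group, so the nearest guide is the exchange of substituted phenyl groups between compound 2 and compound 3, a 1.1-fold lower number from compound 2 to compound 3 (0.03 log units; within the scatter). No change beyond the scatter is expected, and the expected step is a 1.1-fold higher number from compound 3 to compound 4 (0.04 log units; within the scatter). Compound 4 is estimated at 20000 nM, with an expected range of 9000 nM to 40000 nM.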

Compound 4, half-maximal inhibitory concentration: 15800 nM
Compound 4: the middle estimate sits 1.3-fold (0.10 log units) above what was measured; the measured number falls inside the stated range.
By their numbers in this assay, from the lowest: compounds 4, 3, 2 and 1 (each within the scatter of the next, the first and the last beyond it).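

On the oxygen on a saturated carbon, 2-fluoro-4-nitrophenyl reads level with the other two fluorinated groups, with a 1.2-fold lower number from compound 3 to compound 4 (0.06 log units; within the scatter) and a 1.2-fold lower number from compound 2 to compound 4 (0.10 log units; within the scatter) in this assay. A nitro group, with hydrogen-bond acceptors where the leaving group has none, thus shifts nothing beyond the scatter, while the gap to 4-phenylphenyl holds, at a 2.4-fold lower number from compound 1 to compound 4 (0.39 log units; beyond the scatter) and no more. No evidence accounts for these steps.

Going by these compounds, whether an amine or a carboxylic acid on this phenyl ring would behave the same stays open. The compounds shown also do not separate the nitro group from its place on the ring.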